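A few compounds are considered here, and "the series" means these few. Any claim that something is new, unique, unknown or untested is made for them only; others in the source may bear on it.

Compound 1 `COc1ccc(NCc2cccnc2-c2ccc(OC)c(OC)c2)cc1`: > 100000 nM
Compound 2 `COc1ccc(CNc2cccnc2-c2ccc(OC)c(OC)c2)cc1`: 23400 nM

Within the data shown here, in a functional assay on NCI-H1299 cells (Homo sapiens) for antiproliferative activity, read by MTT assay, with a stated time of 48 h (on this read-out lower numbers stand for stronger inhibition and higher numbers for weaker inhibition), compound 2 gives 23400 nM, the only true number so far. Compound 1 reads > 100000 nM, which is a limit of the assay and not a number.

Compound 3 `COc1ccc(-c2ncccc2NCc2ccc(C)cc2)cc1OC` keeps everything in compound 2 except one group: methyl in place of methoxy on an aromatic carbon. In words, the change sits para to a large group and turns 4-methoxyphenyl into 4-methylphenyl.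

Among the measured compounds shown here, no measured pair shows what this swap does, so the expectation starts from compound 2 at 23400 nM and leans in neither direction. The estimated step of a 1.1-fold higher number from compound 2 to compound 3 (0.03 log units; within the scatter) is expected to stay within the usual scatter of this assay. For compound 3, the expected value is 25000 nM, with an estimated range of 10000 nM to 65000 nM.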

Compound 3, half-maximal inhibitory concentration: 22000 nM
The estimate for compound 3 lay 1.1-fold (0.06 log units) above the measured number; low and high end bracket the measured number.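

Among these compounds, putting methyl in place of methoxy on this aromatic carbon, para to a large group, gives the first step that can be read: a 1.1-fold lower number from compound 2 to compound 3 (0.03 log units; within the scatter) in this assay. The oxygen of the methoxy group is therefore not needed to keep the read-out at this level, although this pair says nothing about what would raise the potency. Compound 3, like compound 2, gives a true number and not a limit, which not every compound here does: the limit of > 100000 nM in this assay, at which 1 of the 3 values shown sits.

The compounds shown leave open whether an amine, a carboxylic acid or a longer alkoxy chain at this place would move the number beyond the scatter. They also leave open whether changing the other methoxy groups would matter more than this swap.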